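A few compounds are considered here, and "the series" means these few. Any claim that something is new, unique, unknown or untested is made for them only; others in the source may bear on it.

Compound 1 `Clc1ccc(/C=N/Nc2nc3ccccc3s2)cc1` gives > 17300 nM in a functional assay on HL-60 cells (Homo sapiens) for cytotoxicity, read by MTT assay, with a stated time of 72 h; on this read-out lower numbers stand for stronger inhibition and higher numbers for weaker inhibition. Compound 2 `Clc1ccc(/C=N/Nc2nc3ccccc3s2)c(Cl)c1` gives > 15500 nM. Compound 3 `COc1ccc(/C=N/Nc2nc3ccccc3s2)c(OC)c1` gives > 15900 nM.

Each of these three values is a limit of this assay rather than a number. Compound 1 therefore stands only at such a limit, the one of the limit of > 17300 nM in this assay, at which 1 of the 3 values shown sits. Compound 2 likewise sits at a limit, (the limit of > 15500 nM in this assay, at which 1 of the 3 values shown sits). Compound 3 sits at a limit as well, (the limit of > 15900 nM in this assay, at which 1 of the 3 values shown sits). For the measured compounds named here, the one single-point step, a step that the two limits leave unreadable from compound 1 to compound 2, cannot be read for this reason.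

Compound 4 `C(=N/Nc1nc2ccccc2s1)\c1ccc(-c2ccccn2)cc1` differs from compound 1 by pyridin-2-yl in place of chloro on an aromatic carbon. Going by the values given here, no measured step speaks to a pyridin-2-yl entering at this place, and the chloro step gives no size. Compound 4 is therefore expected to stay near the limit, estimated at 20000 nM with a range from 7000 nM to 60000 nM. The step that the limit leaves unreadable from compound 1 to compound 4 is expected to be nothing beyond the scatter.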

Compound 4, half-maximal inhibitory concentration: 11500 nM
Beside the measured number, compound 4's estimate is 1.7-fold (0.24 log units) above it; low and high end bracket the measured number.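

In this assay compound 4 is the only one of the compounds shown with a value that is a number rather than a limit, so pyridin-2-yl at this place, para to a large group, gives a reading that chloro there did not. The exchange of chloro for pyridin-2-yl gives an at least 1.5-fold lower number from compound 1 to compound 4 (0.17 log units; that floor lies within the scatter). Compound 1 stands only at a limit, so the step has a floor and no true size: the limit of > 17300 nM in this assay, at which 1 of the 4 values shown sits.

As far as these compounds go, how far the step exceeds that floor stays open. Also open, from the compounds shown here alone, is whether a phenyl, a pyridin-4-yl or an amine at this place would read like pyridin-2-yl.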